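The source may report more compounds than this note shows. Statements on the series, on what has been measured and on what is new or still open speak of the compounds shown alone.

Three compounds have been measured in an assay on isolated protein (Mus musculus) for inhibition of IL15-IL15 receptor (Homo sapiens), read by resazurin assay, with stated times of 30 min and 2.5 days; on this read-out higher numbers stand for weaker inhibition and lower numbers for stronger inhibition:

compound 1, `Cn1c(Cc2nn(C)c(=O)c3ccccc23)nnc1SCCCC(=O)Nc1ccc(Cl)cc1Cl`, gives 9800 nM;
compound 2, `Cn1c(Cc2nn(C)c(=O)c3ccccc23)nnc1SCCCCCCCC(=O)Nc1ccc(Cl)cc1Cl`, gives 1900 nM;
compound 3, `Cn1c(Cc2nn(C)c(=O)c3ccccc23)nnc1SCC(=O)Nc1ccc(Cl)cc1Cl`, gives 17300 nM.

Compound 2 stands at the lowest number of the three, so among these it gives the strongest inhibition. Its distance to compound 1 lies beyond the scatter, and its distance to compound 3 is larger still. Among the measured compounds shown here, all three share the same core and carry the same 2,4-dichlorophenyl group on an amide-type nitrogen, so none of the measured steps tells anything about changing that group.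

Compound 4, `Cn1c(Cc2nn(C)c(=O)c3ccccc23)nnc1SCCCCCCCC(=O)Nc1ccccc1O`, has not yet been measured. It differs from compound 2 in one place: 2-hydroxyphenyl in place of 2,4-dichlorophenyl on an amide-type nitrogen

For the measured compounds named here, no measured pair shows a change of this kind, so the direction rests on judgement alone. The expectation is a moderate step towards weaker inhibition, a 2.4-fold higher number from compound 2 to compound 4 (0.37 log units; beyond the scatter), with real uncertainty about its size. Compound 4 is therefore estimated at about 4500 nM in this assay, with a plausible range from 1500 nM to 15000 nM.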

Compound 4, half-maximal inhibitory concentration: 27000 nM
For compound 4 the middle estimate is 6.0-fold (0.78 log units) below the measured one; the measured number lies above the stated range.
By their numbers in this assay, from the lowest: compound 2; then compounds 1, 3 and 4 (each within the scatter of the next, the first and the last beyond it).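

In this assay the group on the amide-type nitrogen turns out to matter: 2-hydroxyphenyl in place of 2,4-dichlorophenyl gives a 14-fold higher number from compound 2 to compound 4 (1.15 log units; beyond the scatter) and so a large step towards weaker inhibition. The earlier compounds shown here all carried 2,4-dichlorophenyl, so they could not show that this end of the molecule is sensitive to change. No supporting data explain the size of this step.

Both changes happen in the same step, so the compounds shown cannot separate the effect of losing the chlorine atoms from that of gaining the hydroxyl group. Also open, from the compounds shown here alone, is how an unsubstituted phenyl ring, a single chlorine or a methoxy group would compare on the same chain.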